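A few compounds are considered here, and "the series" means these few. Any claim that something is new, unique, unknown or untested is made for them only; others in the source may bear on it.

Compound 3 `Cc1nn(-c2ncnc3nc[nH]c23)c2c1C(OCc1ccc(C#N)cc1)CC(=O)N2` gives 4 nM in a functional assay on HEK293 cells for agonist activity at G-protein coupled receptor 39 (Homo sapiens), read by scintillation proximity assay and inositol phosphate accumulation, with a stated time of 75 min, in the presence of a further agent that is not named here (on this read-out lower numbers stand for an effect already at smaller amounts and higher numbers for an effect only at larger amounts of compound), the lowest of the three numbers at hand, although the gap to compound 2 `CCCCCCCCOC1CC(=O)Nc2c1c(C)nn2-c1ncnc2nc[nH]c12`, which gives 8 nM, lies within the scatter; compound 1 `Cc1nn(-c2ncnc3nc[nH]c23)c2c1C(C(=O)Nc1ccccc1)CC(=O)N2` gives 10 nM. Compound 4 `Cc1nn(-c2ncnc3nc[nH]c23)c2c1C(OC(=O)c1ccc(F)cc1)CC(=O)N2` differs from compound 3 by (4-fluorophenyl)carbonyl in place of 4-cyanobenzyl on an oxygen on a saturated carbon. The measured steps that bear on this all touch the same position on the shared core: a 1.3-fold lower number from compound 1 to compound 2 (0.10 log units; within the scatter), a 2.5-fold lower number from compound 1 to compound 3 (0.40 log units; beyond the scatter) and a 2.0-fold lower number from compound 2 to compound 3 (0.30 log units; within the scatter). Each was small or modest, so the change to compound 4 is expected to shift this assay little, if at all, beyond the scatter, perhaps slightly towards higher numbers. The expected step is a 1.8-fold higher number from compound 3 to compound 4 (0.24 log units; within the scatter). Compound 4 is therefore estimated at 7 nM, with a range from 2.5 nM to 20 nM.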

Compound 4, half-maximal effective concentration: 4 nM
Compound 4: the middle estimate sits 1.8-fold (0.24 log units) above what was measured; measured number inside the range.
By their numbers in this assay, from the lowest: compounds 3, 4, 2 and 1 (each within the scatter of the next, the first and the last beyond it).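

In this assay the exchange on this oxygen gives no change at the digits printed from compound 3 to compound 4 (within the scatter) and so shows that, for this pair, an aromatic group attached through a carbonyl and carrying fluorine serves as well as 4-cyanobenzyl. Octyl on the same oxygen gives a 2.0-fold lower number from compound 2 to compound 4 (0.30 log units; within the scatter) while phenylcarbamoyl on the saturated ring carbon gives a 2.5-fold lower number from compound 1 to compound 4 (0.40 log units; beyond the scatter) and thus a second oxygen-linked aromatic group now lies beyond the scatter from that starting point. Nothing at hand explains why these numbers fall as they do. Going by these compounds, it remains open whether a benzoyl group without fluorine would hold the number, and whether a carboxylic acid or an amine on the aromatic ring would be accepted at this oxygen.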